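From 4-(trifluoromethyl)benzyl to cyclopropylmethyl

A few compounds are considered here, and "the series" means these few. Any claim that something is new, unique, unknown or untested is made for them only; others in the source may bear on it.

compound 1 `Cc1cc(Nc2cc(-c3ccccc3)[nH]n2)n2nc(SCc3ccc([N+](=O)[O-])cc3)nc2n1`: 7980 nM
compound 2 `Cc1cc(Nc2cc(-c3ccccc3)[nH]n2)n2nc(SCc3ccc(C(F)(F)F)cc3)nc2n1`: 4240 nM

Both compounds were tested in a functional assay on PC-9 cells (Homo sapiens) for inhibition, read by MTT assay, with a stated time of 72 h; on this read-out lower numbers stand for stronger inhibition and higher numbers for weaker inhibition. Among the compounds with values here, compound 2, at 4240 nM, lies within the scatter of compound 1, the only other compound measured. Compound 3 `Cc1cc(Nc2cc(-c3ccccc3)[nH]n2)n2nc(SCC3CC3)nc2n1` differs from compound 2 as follows: cyclopropyl in place of 4-(trifluoromethyl)phenyl on a saturated chain carbon bound to a sulfur. Within the data shown here, the one measured step, a 1.9-fold lower number from compound 1 to compound 2 (0.27 log units; within the scatter), only exchanges nitro for trifluoromethyl on an aromatic carbon. Among the measured compounds shown here, no measured step removes the aromatic ring, so the direction remains unknown and no step beyond the scatter is expected. The expected change is a 1.4-fold higher number from compound 2 to compound 3 (0.15 log units; within the scatter). For compound 3 the estimate is 6000 nM, with an expected range of 2000 nM to 18000 nM.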

Compound 3, half-maximal inhibitory concentration: > 50000 nM
Compound 3: only a limit was reported; the forecaster's own chance of this, stated with the estimate: 15%; at least 8.3-fold (0.92 log units) between middle value and limit.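

In this assay, compound 3 gives only a limit of the assay, not a number: the limit of > 50000 nM in this assay, at which 1 of the 3 values shown sits. Even so, this change on the saturated chain carbon bound to a sulfur is the first step beyond the scatter, with an at least 11-fold higher number from compound 2 to compound 3 (1.07 log units; beyond the scatter) and an at least 6.2-fold higher number from compound 1 to compound 3 (0.79 log units; beyond the scatter). Compound 1 and compound 2, which both keep the aromatic ring and differ only in its nitro or trifluoromethyl group, lie within the scatter of each other.

The compounds shown leave open whether the aromatic ring alone is enough, as an unsubstituted benzyl group would show. They also leave open how a longer chain, such as hexyl, would read here.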